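Compound 3 and the step to an ester

The source may report more compounds than this note shows. Statements on the series, on what has been measured and on what is new or still open speak of the compounds shown alone.

Compound 1 `CC(C)=CC[C@@H](OC[C@H](C)O)C1=CC(=O)c2c(O)ccc(O)c2C1=O`: 40300 nM
Compound 2 `CC(C)=CC[C@@H](OC(=O)c1ccco1)C1=CC(=O)c2c(O)ccc(O)c2C1=O`: 80300 nM
Compound 3 `CC(C)=CC[C@@H](OCC(C)O)C1=CC(=O)c2c(O)ccc(O)c2C1=O`: 24700 nM

In a functional assay on HeLa cells (Homo sapiens) for cytotoxicity, read by MTT assay (on this read-out higher numbers stand for weaker inhibition and lower numbers for stronger inhibition), compound 3 stands level with compound 1, a 1.6-fold lower number from compound 1 to compound 3 (0.21 log units; within the scatter), and clear of the ester compound 2, a 3.3-fold lower number from compound 2 to compound 3 (0.51 log units; beyond the scatter). Compound 4 `CC[C@@](C)(O)CC(=O)O[C@H](CC=C(C)C)C1=CC(=O)c2c(O)ccc(O)c2C1=O` has not yet been measured. It differs from compound 3 as follows: (2-hydroxy-2-methylbutyl)carbonyl in place of 2-hydroxypropyl on an oxygen on a saturated carbon. Like compound 2, it links its side chain through a carbonyl on that oxygen, so the step of a 3.3-fold lower number from compound 2 to compound 3 (0.51 log units; beyond the scatter) is the closest guide, read in reverse. That guide is a single pair with a furan-2-yl group, quite unlike the open chain entering here, and a 2.0-fold higher number from compound 1 to compound 2 (0.30 log units; within the scatter) is a smaller gap. Among the measured compounds shown here, the one stereo comparison available, a 1.6-fold lower number from compound 1 to compound 3 (0.21 log units; within the scatter), gives no reason to expect much from the new defined stereocentre. Only a small shift towards a higher number is therefore expected, a 1.8-fold higher number from compound 3 to compound 4 (0.26 log units; within the scatter). For compound 4 the estimated value is 45000 nM, with an expected range from 15000 nM to 110000 nM.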

Compound 4, half-maximal inhibitory concentration: 17900 nM
For compound 4 the middle estimate is 2.5-fold (0.40 log units) above the measured one; measured number inside the range.
By their numbers in this assay, from the lowest: compounds 4, 3, 1 and 2 (each within the scatter of the next, the first and the last beyond it).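

In this assay, (2-hydroxy-2-methylbutyl)carbonyl in place of 2-hydroxypropyl on the oxygen leaves compound 4 level with compound 3: a 1.4-fold lower number from compound 3 to compound 4 (0.14 log units; within the scatter). A carbonyl on this oxygen therefore does not by itself bring the high number of compound 2, since 2-hydroxy-2-methylbutyl in place of furan-2-yl on the carbonyl carbon gives a 4.5-fold lower number from compound 2 to compound 4 (0.65 log units; beyond the scatter), so the group on that carbonyl matters among these esters. The same side-chain exchange measured from compound 1 gives a 2.3-fold lower number from compound 1 to compound 4 (0.35 log units; beyond the scatter), so this position accepts the larger open chain without any step towards a higher number.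

Nothing given here accounts for these steps. On these data alone, whether an acetyl group, or an open chain carrying an amine instead of the hydroxyl, would stay level with compound 4 remains open, as does the role of the defined stereocentre in its chain.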